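This account rests on a few compounds, and the source may have more. Where it says the series, first, only, none or still open, it means among the compounds named here.

Measured compounds:
Compound 1, `CC1(C)[C@H]2CC[C@]1(C)N(Cc1cn(-c3ccc(Cl)cc3)nn1)C(=O)C2`, gives 410 nM in a functional assay on SGC-7901 cells (Homo sapiens) for inhibition, read by MTT assay, with a stated time of 24 h; on this read-out lower numbers stand for stronger inhibition and higher numbers for weaker inhibition.
Compound 2, `CC1(C)[C@H]2CC[C@]1(C)N(Cc1cn(-c3ccccc3O)nn1)C(=O)C2`, gives 410 nM in this assay.
Compound 3, `CC1(C)[C@H]2CC[C@]1(C)N(Cc1cn(-c3ccccc3Cl)nn1)C(=O)C2`, gives 220 nM in this assay.

All three share one core and differ only in the aromatic group attached to a ring nitrogen. Compound 3 has the lowest of the three numbers, but neither gap sets it apart: the step of a 1.9-fold lower number from compound 1 to compound 3 (0.27 log units; within the scatter) and the step of a 1.9-fold lower number from compound 2 to compound 3 (0.27 log units; within the scatter) are both within the scatter, so the three compounds cannot be ranked.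

Compound 4, `CC1(C)[C@H]2CC[C@]1(C)N(Cc1cn(-c3ccc(O)cc3)nn1)C(=O)C2`, has not yet been measured. It differs from compound 3 by 4-hydroxyphenyl in place of 2-chlorophenyl on an aromatic nitrogen.

For the measured compounds named here, two measured steps bear on this change. The step of no change at the digits printed from compound 1 to compound 2 (within the scatter) shows that exchanging a 4-chlorophenyl for a 2-hydroxyphenyl left the number unchanged, and the step of a 1.9-fold lower number from compound 2 to compound 3 (0.27 log units; within the scatter) shows that hydroxy against chloro also stayed within the scatter. Compound 4 combines the hydroxy group of compound 2 with the placement found in compound 1, both of which gave the same value. No step beyond the scatter is therefore expected: the estimated step is a 2.0-fold higher number from compound 3 to compound 4 (0.31 log units; beyond the scatter).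

Compound 4 is expected to give about 450 nM in this assay, within a range of 220 nM to 900 nM.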

Compound 4, half-maximal inhibitory concentration: 330 nM
Compound 4: middle estimate off by 1.4-fold (0.13 log units), on the high side; measured number inside the range.
By their numbers in this assay, from the lowest: compounds 3, 4, 1 and 2 (each within the scatter of the next).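

With compound 4, the phenyl group on the aromatic nitrogen has now been seen as 2-chlorophenyl, 4-chlorophenyl, 2-hydroxyphenyl and 4-hydroxyphenyl, and in this assay no single change among these four separates two compounds beyond the scatter. Putting 4-hydroxyphenyl in place of 2-hydroxyphenyl gives a 1.2-fold lower number from compound 2 to compound 4 (0.09 log units; within the scatter), putting 4-hydroxyphenyl in place of 4-chlorophenyl gives a 1.2-fold lower number from compound 1 to compound 4 (0.09 log units; within the scatter), and putting 4-hydroxyphenyl in place of 2-chlorophenyl gives a 1.5-fold higher number from compound 3 to compound 4 (0.18 log units; within the scatter). The exchange of chloro and hydroxy can now be read in two settings, and the two readings give no sign that its outcome depends on where the group sits on the phenyl ring: the same change on two cores in this assay, a 1.9-fold lower number (0.27 log units; within the scatter) from compound 2 to compound 3 and a 1.2-fold higher number (0.09 log units; within the scatter) from compound 4 to compound 1, 2.3-fold (0.36 log units) apart, within the scatter of two such steps.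

All four compounds carry a phenyl group with either chloro or hydroxy, so they cannot show whether this position responds to a larger change or tolerates almost anything. An amine or a carboxylic acid on the phenyl ring, or a longer chain on the aromatic nitrogen in place of the phenyl group, could show whether the number in this assay can move beyond the scatter at all.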